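The source may hold more compounds than are shown below. What is called first, only, known or untested is meant among the compounds shown, and "the series" means these compounds.

Of the compounds shown here, two built on the same core have been tested in an assay on mitochondria from L6 cells (Rattus norvegicus) for activation, with a stated time of 90 min; a lower number here means that less compound is needed, a higher number that more compound is needed for the effect. Compound 1 `COc1ccc(Nc2nc3nonc3nc2Nc2ccccc2F)cc1` gives 1600 nM. Compound 2 `CCOc1ccc(Nc2nc3nonc3nc2Nc2ccccc2F)cc1` gives 3800 nM. The step between them is a 2.4-fold higher number from compound 1 to compound 2 (0.38 log units; beyond the scatter). Among these two numbers compound 2 stands at the higher one, so more of it is needed for the effect than of compound 1.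

Compound 3 `O=C(Nc1ccc(Nc2nc3nonc3nc2Nc2ccccc2F)cc1)C(F)(F)F` has not yet been measured. It differs from compound 2 in one place: ((trifluoromethyl)carbonyl)amino in place of ethoxy on an aromatic carbon. The entering group brings a hydrogen-bond donor, which the leaving ethoxy lacks. Within the data shown here, the only measured step, a 2.4-fold higher number from compound 1 to compound 2 (0.38 log units; beyond the scatter), concerns methyl in place of hydrogen on the chain and says little about exchanging the whole group, so no firm direction follows from it. Compound 3 is therefore expected to show a 1.5-fold lower number from compound 2 to compound 3 (0.18 log units; within the scatter) in this assay, with wide uncertainty. The estimate for compound 3 in this assay is 2500 nM, with a range from 700 nM to 9000 nM.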

Compound 3, half-maximal effective concentration: 4100 nM
Compound 3: the middle estimate sits 1.6-fold (0.21 log units) below what was measured; measured number inside the range.
By their numbers in this assay, from the lowest: compound 1; then compounds 2 and 3 (each within the scatter of the next).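

On this aromatic carbon, para to a large group, the change is far bigger than adding a single methyl: in this assay, ((trifluoromethyl)carbonyl)amino in place of ethoxy brings in more heavy atoms and a hydrogen-bond donor, yet gives a 1.1-fold higher number from compound 2 to compound 3 (0.03 log units; within the scatter). The same group in place of methoxy gives a 2.6-fold higher number from compound 1 to compound 3 (0.41 log units; beyond the scatter), so among these three compounds methoxy goes with the lowest number, while ethoxy and ((trifluoromethyl)carbonyl)amino cannot be told apart. Nothing available explains why these two quite different groups read alike.

Still open, from the compounds shown here alone, is whether a free amine, a carboxylic acid or a longer alkoxy chain at this position would follow the same picture. Going by these compounds, it is also open whether a plain acetyl amide would read like compound 3, which would show what the trifluoromethyl part contributes.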